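The source may report more compounds than this note shows. Statements on the series, on what has been measured and on what is new or still open speak of the compounds shown alone.

Compound 1 `Cn1c(Cc2nn(CCC3OCCO3)c(=O)c3ccccc23)nnc1SCC(=O)Nc1ccc(Cl)cc1Cl` and compound 2 `CN(C)CCCn1nc(Cc2nnc(SCCCCCCCC(=O)Nc3ccc(Cl)cc3Cl)n2C)c2ccccc2c1=O` share the same core. In an assay on NK92 cells for inhibition of interleukin-2 (Homo sapiens), read by AlphaScreen, with stated times of 30 min and 1 h (a lower number here means a stronger inhibitor, a higher number a weaker inhibitor), compound 1 gives only a limit of the assay, > 30000 nM. In this assay compound 2 likewise gives only a limit, > 30000 nM. Compound 2 therefore stands where every value shown so far sits (the limit of > 30000 nM in this assay, at which 2 of the 2 values shown sit). Compound 3 `Cn1c(Cc2nn(CCC(=O)O)c(=O)c3ccccc23)nnc1SCCCCCCCC(=O)Nc1ccc(Cl)cc1Cl` is the next to be measured. It differs from compound 2 by carboxy in place of (dimethylamino)methyl on a saturated chain carbon, two bonds along the chain from an aromatic nitrogen. For the measured compounds named here, no step between measured compounds exists to guide the size of this change, so no shift beyond the scatter is expected. The change is estimated to amount to a step that the limit leaves unreadable from compound 2 to compound 3. Compound 3 is expected at 40000 nM, between 10000 nM and 150000 nM, most probably again reported as a limit.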

Compound 3, half-maximal inhibitory concentration: 30000 nM
Estimate against measurement, compound 3: 1.3-fold (0.12 log units) above; the measured number falls inside the stated range.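

In this assay, for the compounds shown here, compound 3 gives a measured number, 30000 nM, the first value here that is not a limit. Compound 2 gives > 30000 nM, which is only a limit of the assay. The change from (dimethylamino)methyl to carboxy at this position, on a saturated chain carbon, two bonds along the chain from an aromatic nitrogen, gives a number no higher from compound 2 to compound 3 (the limit leaves the size open), and the measured number stands at the same figure as the limit: the limit of > 30000 nM in this assay, at which 2 of the 3 values shown sit.

On these data alone, whether carboxy truly improves on (dimethylamino)methyl at this position stays open. So does how a methyl ester or a primary amide would read there.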